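Chain Lengthening and Tolerated Concentration in Kidney Cells

The source may hold more compounds than are shown below. What is called first, only, known or untested is meant among the compounds shown, and "the series" means these compounds.

Three compounds were measured in an ADME assay on MDCK cells (Canis lupus familiaris) for cytotoxicity, read by microscopy, with a stated time of 6 days; a lower number here means that less compound is tolerated, a higher number that more compound is tolerated.
Compound 1 `CCCCCNc1cnc(C(=O)NCc2ccccc2)cn1` gives > 100000 nM, which is a limit of the assay and not a number.
Compound 2 `CCCCNc1cnc(C(=O)NCc2ccccc2)cn1` gives 100000 nM.
Compound 3 `CCCCCCNc1nccnc1C(=O)NCc1ccccc1` gives 100000 nM.

Compound 2 and compound 1 differ in one place: methyl in place of hydrogen on a saturated chain carbon, four bonds along the chain from a nitrogen on an aromatic ring. In this assay the step of a number no lower from compound 2 to compound 1 (the limit leaves the size open), and its size cannot be read because compound 1 sits at the limit of > 100000 nM in this assay, at which 1 of the 3 values shown sits. Compound 3 is level with compound 2 at the digits given, within the usual scatter; the difference between the two cores is not broken down here.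

Compound 4 `CCCCCCCNc1nccnc1C(=O)NCc1ccccc1` has not been measured. It differs from compound 3 by methyl in place of hydrogen on a saturated chain carbon, six bonds along the chain from a nitrogen on an aromatic ring. This is the same kind of change as that from compound 2 to compound 1, but it sits six bonds along the chain rather than four. The expectation rests on compound 3 at 100000 nM and on the measured step, which left the size open. Compound 4 is expected to give 100000 nM, between 50000 nM and 200000 nM. Beside the measured step, the step that this estimate means is expected to be no change at the digits printed from compound 3 to compound 4 (within the scatter).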

Compound 4, minimum cytotoxic concentration: 100000 nM
The estimate for compound 4 equals the measured number at the digits printed; the measured number falls inside the stated range.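

Carried onto the core of compound 3, the added methyl gave, in this assay, no change at the digits printed from compound 3 to compound 4 (within the scatter), so on this core the change leaves the tolerated concentration where it was. Compound 1 gives > 100000 nM, which is a limit of the assay and not a number, and the size of the earlier step therefore cannot be read: the limit of > 100000 nM in this assay, at which 1 of the 4 values shown sits. The comparison thus does not show that the change carries from one core to the other with the same size, nor that it behaves differently on the two cores: the same change on two cores in this assay, a number no lower (the limit leaves the size open) from compound 2 to compound 1 and no change at the digits printed (within the scatter) from compound 3 to compound 4; the limit leaves it open whether they differ.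

The compounds shown leave open whether a chain longer than that of compound 4, or one ending in a hydroxyl group, an amine or a carboxylic acid, would stay level with compound 3 in this assay. They also leave open whether a branched chain or a chain ending in a phenyl ring would do the same on either core.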